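Exchanging a Pyridine Substituent on a Fused Core

This account rests on a few compounds, and the source may have more. Where it says the series, first, only, none or still open, it means among the compounds named here.

Compound 2: `CCCN(CCC)c1cc(C)nc2c(-c3ncc(I)cc3C)c(C)nn12`, 6.6 nM
Compound 1: `CCCN(CCC)c1cc(C)nc2c(-c3ncc(C)cc3[N+](=O)[O-])c(C)nn12`, 14 nM

In an assay on isolated protein for binding affinity to corticotropin-releasing factor receptor 1 (Homo sapiens) (a higher number here means a weaker inhibitor, a lower number a stronger inhibitor), compound 2 gives the lower of the two numbers shown; compound 1 sits higher, with the gap between them beyond the scatter. Compound 3 is `CCCN(CCC)c1cc(C)nc2c(-c3ncc(C)cc3N=O)c(C)nn12`. Relative to compound 2 the change is a group of 9 heavy atoms (6 carbon, 2 nitrogen, 1 oxygen; one six-membered aromatic ring with 1 hetero atom) in place of a group of 8 heavy atoms (6 carbon, 1 nitrogen, 1 iodine; one six-membered aromatic ring with 1 hetero atom), on an aromatic carbon, on an aromatic carbon of the shared core. Within the data shown here, no comparable step between measured compounds is available, so the expectation rests on the two values alone. The step from compound 2 to compound 3 is estimated as a 3.0-fold higher number from compound 2 to compound 3 (0.48 log units; beyond the scatter), a mild weakening. For compound 3 the expected value in this assay is 20 nM, within 7 nM to 60 nM.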

Compound 3, inhibition constant: > 10000 nM
Compound 3: a limit, no number (the forecaster's own chance of this, stated with the estimate: 5%); middle value at least 500-fold (2.69 log units) away from the limit.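

In this assay, compound 3 gives only a limit, not a number: the limit of > 10000 nM in this assay, at which 1 of the 3 values shown sits. Changing the pyridine group gives an at least 1500-fold higher number from compound 2 to compound 3 (3.18 log units; beyond the scatter), and replacing the nitro group with a nitroso group gives an at least 710-fold higher number from compound 1 to compound 3 (2.85 log units; beyond the scatter). So the two earlier compounds showed this pyridine position carrying quite different groups, while this small change on the same ring removes nearly all measurable binding.

As far as these compounds go, whether an amine or a methoxy group in that place would restore binding stays open. The reason for the loss also stays open, since these three compounds do not reveal it.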